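A pyridin-4-yl in place of bromo

The source may report more compounds than this note shows. Statements on the series, on what has been measured and on what is new or still open speak of the compounds shown alone.

Compound 1 `COC(=O)N[C@H](C(=O)NN(CCC[C@@](O)(Cc1ccccc1)C(=O)N[C@H]1c2ccccc2C[C@H]1O)Cc1ccc(Br)cc1)C(C)(C)C`: > 20 10^-6 cm/s
Compound 2 `COC(=O)N[C@H](C(=O)NN(CCC[C@@](O)(Cc1ccccc1)C(=O)N[C@H]1c2ccccc2C[C@H]1O)Cc1ccc(-c2nccs2)cc1)C(C)(C)C`: > 20 10^-6 cm/s

In an ADME assay on Caco-2 cells (Homo sapiens) for permeability, in the apical to basolateral direction (a lower number here means that the compound crosses the layer more slowly, a higher number that the compound crosses the layer faster), compound 1 gives > 20 10^-6 cm/s, which is a limit of the assay and not a number. Compound 2 gives > 20 10^-6 cm/s, and this too is a limit. The only reference point is therefore (the limit of > 20 10^-6 cm/s in this assay, at which 2 of the 2 values shown sit).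

Compound 3 `COC(=O)N[C@H](C(=O)NN(CCC[C@@](O)(Cc1ccccc1)C(=O)N[C@H]1c2ccccc2C[C@H]1O)Cc1ccc(-c2ccncc2)cc1)C(C)(C)C` has not yet been measured. It carries pyridin-4-yl in place of bromo on an aromatic carbon, para to a large group: pyridin-4-yl in place of bromo on an aromatic carbon. Going by the values given here, the one measured step that bears on this change is a step that the two limits leave unreadable from compound 1 to compound 2, with 1,3-thiazol-2-yl entering at the same place. Its size cannot be read, so it gives no direction.

Compound 2 still reports a limit, > 20 10^-6 cm/s, so compound 3 is expected to stay close to that limit as well. No change beyond the scatter is expected in this assay, and the expected step is a step that the limit leaves unreadable from compound 1 to compound 3. For compound 3 the estimated value is 24 10^-6 cm/s, with an expected range from 10 10^-6 cm/s to 45 10^-6 cm/s.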

Compound 3, apparent permeability: < 20 10^-6 cm/s
Compound 3 ended at the assay's limit (the forecaster's own chance of this, stated with the estimate: 60%); middle value at least 1.2-fold (0.07 log units) from the limit.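

At this position, on an aromatic carbon para to a large group, the result gives the first sign in this assay that the group carried there can matter: the reading goes a number no higher from compound 1 to compound 3 (the limit leaves the size open), and likewise a number no higher from compound 2 to compound 3 (the limit leaves the size open), although all the values are limits and the size of every step among these compounds cannot be read. It also shows that two aromatic rings entering at the same place need not fall on the same side of the limit, as 1,3-thiazol-2-yl stays on the upper side with bromo while pyridin-4-yl does not. Compound 3 therefore stands alone on its side of the limit, and the two sides are now both occupied: the limit of < 20 10^-6 cm/s in this assay, at which 1 of the 3 values shown sits.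

The compounds shown leave open how far compound 3 actually lies from compound 1 or compound 2, as no step here has a readable size. They also leave open whether the ring nitrogen of pyridin-4-yl is what separates compound 3, and whether a plain phenyl or a pyridin-3-yl at the same place would read with compound 2 or with compound 3.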